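Swapping a Pyridine for a Furan on the Piperazine Arm

This account rests on a few compounds, and the source may have more. Where it says the series, first, only, none or still open, it means among the compounds named here.

Of the compounds shown here, two sharing one core have been measured in an assay on CHO cells for displacement of a labelled ligand from 5-hydroxytryptamine receptor 1B (Homo sapiens); on this read-out higher numbers stand for weaker inhibition and lower numbers for stronger inhibition. Compound 1 `c1ccc(CN2CCN(CCCc3c[nH]c4ccc(-n5cnnc5)cc34)CC2)nc1` carries a pyridin-2-ylmethyl group on the amine nitrogen in a ring, and in this assay compound 1 gives 18 nM. Compound 2 `c1cc(CN2CCN(CCCc3c[nH]c4ccc(-n5cnnc5)cc34)CC2)ccn1` carries a pyridin-4-ylmethyl group at the same place, and in this assay compound 2 gives 23 nM. Compound 2 thus holds the higher of the two numbers, but the gap to compound 1 is within the scatter, so the two cannot be told apart.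

Compound 3 `c1coc(CN2CCN(CCCc3c[nH]c4ccc(-n5cnnc5)cc34)CC2)c1` has not yet been measured. It differs from compound 2 by furan-2-yl in place of pyridin-4-yl on a saturated chain carbon bound to an amine nitrogen in a ring. Within the data shown here, the one measured step at this position, a 1.3-fold higher number from compound 1 to compound 2 (0.11 log units; within the scatter), exchanged one pyridyl ring for another and stayed within the scatter; it does not test a five-membered ring or the loss of a ring atom, so it guides only loosely. On that basis a step of a 1.3-fold higher number from compound 2 to compound 3 (0.12 log units; within the scatter) is expected, within the scatter rather than beyond it. Compound 3 is therefore estimated at 30 nM, with a range from 12 nM to 75 nM.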

Compound 3, half-maximal inhibitory concentration: 18 nM
The estimate for compound 3 lay 1.7-fold (0.22 log units) above the measured number, within the range that was stated.
By their numbers in this assay, from the lowest: compounds 1, 3 and 2 (each within the scatter of the next).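

In this assay the change to a five-membered ring gives a 1.3-fold lower number from compound 2 to compound 3 (0.11 log units; within the scatter), and measured against the other pyridine it gives no change at the digits printed from compound 1 to compound 3 (within the scatter). The earlier step only exchanged one pyridyl ring for another, whereas these steps also change the ring size and replace the ring nitrogen with an oxygen, yet all three compounds remain within the scatter of one another, so at this place, on a saturated chain carbon bound to an amine nitrogen in a ring, furan-2-yl cannot be told apart from either pyridyl group. Nothing available explains why these different rings give such similar numbers.

Going by these compounds, all three compounds carry an aromatic ring with one hetero atom, so it remains open whether a plain phenyl ring, a saturated ring such as tetrahydrofuran, or a simple methyl group at the same place would stay within the scatter of these numbers. On these data alone, every number also comes from this one receptor, so how these three compounds compare on any other receptor remains unknown.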